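The source may report more compounds than this note shows. Statements on the series, on what has been measured and on what is new or still open speak of the compounds shown alone.

Of the compounds shown here, two of this small set have been measured in an ADME assay on HEp-2 cells (Homo sapiens) for cytotoxicity, read by MTT assay, with a stated time of 3 days; on this read-out higher numbers stand for lower toxicity in this test and lower numbers for higher toxicity in this test. Compound 1, `CC[C@@H](CCn1cncn1)c1ccc(C)cc1`, gives 69.9 ug/mL in this assay. Compound 2, `CCC[C@H](CCn1cncn1)c1ccc(C)cc1`, gives 45.7 ug/mL in this assay, the lowest of the two numbers, with compound 1 the nearest, the gap between them lying within the usual scatter, so the two cannot be told apart. Compound 3, `CCC[C@@H](CCn1cncn1)c1ccc(C)cc1`, is the next compound to be measured. It is built from compound 2 without any group leaving or entering: the two compounds have the same atoms and bonds and differ only in configuration as drawn: 1 of 1 stereo elements differ; a stereocentre at a saturated chain carbon is drawn R in compound 2 and S in compound 3. Among the measured compounds shown here, no measured pair with such a change is available here, so the expectation rests only on the shared atoms and bonds. The expected step, a 1.0-fold higher number from compound 2 to compound 3 (0.00 log units; within the scatter), is therefore small and stays within the usual scatter of this assay. For compound 3 the estimated value in this assay is 46 ug/mL, with a range from 22 ug/mL to 95 ug/mL.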

Compound 3, half-maximal cytotoxic concentration: 71.3 ug/mL
Beside the measured number, compound 3's estimate is 1.6-fold (0.19 log units) below it; low and high end bracket the measured number.
By their numbers in this assay, from the lowest: compounds 2, 1 and 3 (each within the scatter of the next).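

Turning the stereocentre at the saturated chain carbon from R to S gives a 1.6-fold higher number from compound 2 to compound 3 (0.19 log units; within the scatter), so in this assay this change of configuration does not separate the two compounds. Among the compounds shown here, this pair is the first to test this change on its own, and nothing else distinguishes its members: the fact that compounds 2 and 3 differ only in the configuration as drawn. Methyl in place of hydrogen on a saturated chain carbon, three bonds along the chain from an aromatic carbon, gives a 1.0-fold higher number from compound 1 to compound 3 (0.01 log units; within the scatter), so that change cannot be told apart from scatter either.

On these data alone, all three compounds lie close together, so it remains open whether a larger change at this carbon, such as a longer chain or an amine, would move the number clearly. As far as these compounds go, the counterpart of compound 1 with the opposite configuration also remains open.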